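The source may report more compounds than this note shows. Statements on the series, on what has been measured and on what is new or still open speak of the compounds shown alone.

Working notes on the series. Compound 1 `CCCCC(Sc1ccc(OCCCOc2ccc(-c3ccccc3)cc2)cc1)C(=O)O` gives 3500 nM in an assay for inhibition of Polyunsaturated fatty acid 5-lipoxygenase (Homo sapiens), read by HPLC, with a stated time of 10 min; a lower number here means a stronger inhibitor, a higher number a weaker inhibitor. Compound 2 `CCCCC(Sc1ccc(OCCCOc2cccc3c2CCCC3)cc1)C(=O)OCC` reports only a limit in this assay, > 10000 nM. Compound 3 `CCCCC(Sc1ccc(OCCCOc2ccc(Cl)cc2OC)cc1)C(=O)O` likewise sits at a limit in this assay, > 10000 nM. Two of the three values shown rest at this limit, (the limit of > 10000 nM in this assay, at which 2 of the 3 values shown sit), so compound 3 stands at the ceiling of this assay with no number of its own to anchor a step.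

Compound 4 `CCCCC(Sc1ccc(OCCCOc2cccc(C(C)C)c2)cc1)C(=O)O` differs from compound 3 by 3-isopropylphenyl in place of 4-chloro-2-methoxyphenyl on an oxygen on a saturated carbon. Among the compounds with values here, no measured pair isolates a change of this kind, so the size of the step is open. Among the acids, compound 1 carries an aryl of carbon only and returns a number, whereas compound 3 carries the chloro-methoxy aryl and returns only a limit; on that slim basis a move into the measurable range is plausible, though a second limit remains quite possible. The step from compound 3 to compound 4 is expected to be an at least 2.0-fold lower number from compound 3 to compound 4 (0.30 log units; that floor lies within the scatter). The estimate for compound 4 in this assay is 5000 nM, expected between 1500 nM and 15000 nM.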

Compound 4, half-maximal inhibitory concentration: 6000 nM
The estimate for compound 4 lay 1.2-fold (0.08 log units) below the measured number; low and high end bracket the measured number.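

Replacing 4-chloro-2-methoxyphenyl with 3-isopropylphenyl on an oxygen on a saturated carbon takes this acid from a limit to a number in this assay, with an at least 1.6-fold lower number from compound 3 to compound 4 (0.22 log units; that floor lies within the scatter). Compound 3 holds only a limit, so this step is a floor and its full size cannot be read: the limit of > 10000 nM in this assay, at which 2 of the 4 values shown sit. Compound 1 gives 3500 nM and compound 4 gives 6000 nM, so both acids shown with an aryl of carbon only return numbers, whereas compound 3, with chlorine and oxygen on its aryl, does not.

As far as these compounds go, the chloro and methoxy groups leave together in this single step, so their separate contributions remain open. Also open, from the compounds shown here alone, is how a trifluoromethyl group or an amine would read in place of the isopropyl group.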